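Swapping an Aryl Amide for a Pyridazine Amide

This account rests on a few compounds, and the source may have more. Where it says the series, first, only, none or still open, it means among the compounds named here.

Of the compounds shown here, two built on a shared core have been tested in an assay on CHO cells for positive allosteric modulation of metabotropic glutamate receptor 5 (Homo sapiens), read by FLIPR; on this read-out lower numbers stand for an effect already at smaller amounts and higher numbers for an effect only at larger amounts of compound. Compound 1 `O=C(Nc1cccc(F)c1CN1C(=O)c2ccccc2C1=O)c1ccccn1` reaches only the limit of the measurement, giving > 100000 nM in this assay. Among the measured compounds shown here, compound 2 `O=C(Nc1ccc(Cl)cc1CN1C(=O)c2ccccc2C1=O)c1ccccc1C(F)(F)F` is the only one with a measured number, giving 5700 nM in this assay. Compound 3 `O=C(Nc1ccc(Cl)cc1CN1C(=O)c2ccccc2C1=O)c1cccnn1` differs from compound 2 at a single place: pyridazin-3-yl in place of 2-(trifluoromethyl)phenyl on a carbonyl carbon. For the measured compounds named here, no measured pair differs in the same way, so the size of this step is open. Compound 1, which sits at the limit (the limit of > 100000 nM in this assay, at which 1 of the 2 values shown sits), also carries a nitrogen-containing ring on the carbonyl carbon but differs elsewhere too, so it offers no direct guidance. The step is expected to weaken the effect, a 5.3-fold higher number from compound 2 to compound 3 (0.72 log units; beyond the scatter). Compound 3 is therefore estimated at 30000 nM, in a range from 6000 nM to 100000 nM, with a real chance that only a limit is reported.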

Compound 3, half-maximal effective concentration: > 100000 nM
Compound 3 gave a limit, no number (the forecaster's own chance of this, stated with the estimate: 40%); middle value at least 3.3-fold (0.52 log units) away from the limit.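

At this place on the carbonyl carbon, the group matters in this assay: pyridazin-3-yl in place of 2-(trifluoromethyl)phenyl gives an at least 17-fold higher number from compound 2 to compound 3 (1.24 log units; beyond the scatter). Compound 1 could not show this, as it differs from compound 2 in more than one place. The value of compound 3, > 100000 nM, is a limit and not a number, so the step gives only a smallest possible size, and limits now make up most of the results: the limit of > 100000 nM in this assay, at which 2 of the 3 values shown sit.

On these data alone, it remains open whether the effect of compound 2 depends on the trifluoromethyl group, on the carbon-only ring, or on both. A plain phenyl group or a methoxyphenyl group on the same carbonyl carbon, with the rest of compound 2 unchanged, would help to separate these possibilities.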